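Swapping the aryl group on a five-membered ring in compound 3

This account rests on a few compounds, and the source may have more. Where it says the series, first, only, none or still open, it means among the compounds named here.

Of the compounds shown here, three sharing a related skeleton have been tested in a functional assay on MDA-MB-231 cells (Homo sapiens) for cytotoxicity, read by MTT assay, with a stated time of 48 h; a higher number here means a weaker inhibitor, a lower number a stronger inhibitor. Compound 1 `COc1cc(-n2nnnc2-c2ccc(OCC3CC(c4cccc(Cl)c4)=NO3)c(N)c2)cc(OC)c1OC` gives 2180 nM, and compound 2 `COc1cc(C2=NOC(c3cc(OC)c(OC)c(OC)c3)C2)ccc1O` gives 3600 nM. Compound 3 `COc1cc(-n2nnnc2-c2ccc(OCC3CC(c4ccc(C(F)(F)F)cc4)=NO3)c(N)c2)cc(OC)c1OC` gives 1750 nM, the lowest of the three numbers; its gap to compound 1 is within the scatter, while its gap to compound 2 is beyond it.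

Among the compounds with values here, compound 4 `COc1cc(-n2nnnc2-c2ccc(OCC3CC(c4ccc(OC)c(OC)c4OC)=NO3)c(N)c2)cc(OC)c1OC` is the next compound, not yet measured. 2,3,4-trimethoxyphenyl in place of 4-(trifluoromethyl)phenyl on a carbon with a double bond to nitrogen The one earlier step that touches this position is the aryl swap a 1.2-fold lower number from compound 1 to compound 3 (0.10 log units; within the scatter), which changed the number by very little. Within the data shown here, compound 2, which carries a trimethoxyphenyl group at a different place, is the only other hint, and no step to it is defined. The expectation is therefore a step of about a 1.1-fold higher number from compound 3 to compound 4 (0.06 log units; within the scatter), which is to say no change beyond the scatter. Compound 4 is estimated at 2000 nM, with a likely range from 900 nM to 4500 nM.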

Compound 4, half-maximal inhibitory concentration: 3540 nM
Estimate against measurement, compound 4: 1.8-fold (0.25 log units) below; the measured number falls inside the stated range.
By their numbers in this assay, from the lowest: compounds 3, 1, 4 and 2 (each within the scatter of the next, the first and the last beyond it).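

In this assay, the aryl group on the carbon with a double bond to nitrogen proves able to move the number beyond the scatter: 2,3,4-trimethoxyphenyl in place of 4-(trifluoromethyl)phenyl gives a 2.0-fold higher number from compound 3 to compound 4 (0.31 log units; beyond the scatter). Set against 3-chlorophenyl, the same group gives only a 1.6-fold higher number from compound 1 to compound 4 (0.21 log units; within the scatter), so the evidence that this position matters rests on a single modest step. The entering group carries hydrogen-bond acceptors and the leaving group has none, but no measurement here ties the step to that difference or to any other cause. Going by these compounds, it remains open whether all the methoxy groups are needed for this shift, or how a phenyl ring with a single methoxy group would compare. Also open, on these data alone, is what an amine or a carboxylic acid on this aryl ring would do to the number.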